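Three Measured Compounds, One Change, and an Expected Fourth

A few compounds are considered here, and "the series" means these few. Any claim that something is new, unique, unknown or untested is made for them only; others in the source may bear on it.

Compound 1, `Cc1ccc(NC(=S)OCCc2ccccc2)cc1`, was tested in an ADME assay on MT4 cells (Homo sapiens) for cytotoxicity, read by MTT assay; on this read-out lower numbers stand for higher toxicity in this test and higher numbers for lower toxicity in this test. In this assay compound 1 gives > 100000 nM, which is a limit of the assay rather than a number. Compound 2, `S=C(Nc1ccc(Cl)cc1)OCCc1ccccc1`, carries one change against compound 1: chloro in place of methyl on an aromatic carbon. In this assay compound 2 gives > 100000 nM, again a limit rather than a number. The step that the two limits leave unreadable from compound 1 to compound 2 can therefore not be read in size. Compound 3, `Cc1ccc(NC(=S)OCCc2ccncc2)cc1`, differs from compound 1 in its core: pyridin-4-yl in place of phenyl on a saturated chain carbon, two bonds along the chain from an oxygen on an unsaturated carbon. In this assay compound 3 gives > 100000 nM, once more a limit. The step that the two limits leave unreadable from compound 1 to compound 3 is likewise unreadable. What ties the three together is the limit of > 100000 nM in this assay, at which 3 of the 3 values shown sit.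

Compound 4, `S=C(Nc1ccc(Cl)cc1)OCCc1ccncc1`, has not yet been measured in this assay. It carries the same change that turns compound 1 into compound 2, now made on the core of compound 3: chloro in place of methyl on an aromatic carbon. The place of the change is the same, word for word, in both cases, so this is the same change and not merely the same kind. The step that the limit leaves unreadable from compound 3 to compound 4 is expected to be small or absent. This expectation rests on compound 2, which after the same change gives > 100000 nM, and on (the limit of > 100000 nM in this assay, at which 3 of the 3 values shown sit). In this assay compound 4 is expected to give 200000 nM, with a likely range from 80000 nM to 500000 nM.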

Compound 4, half-maximal cytotoxic concentration: 70000 nM
The estimate for compound 4 lay 2.9-fold (0.46 log units) above the measured number; measured number outside the range, below it.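

In this assay, chloro in place of methyl gives an at least 1.4-fold lower number from compound 3 to compound 4 (0.15 log units; that floor lies within the scatter), and pyridin-4-yl in place of phenyl gives an at least 1.4-fold lower number from compound 2 to compound 4 (0.15 log units; that floor lies within the scatter). Within the data shown here, the same change that gave no readable step on the core of compound 1 ends in a measured number on the core of compound 3, and compound 4 alone among the four has a number rather than a limit of the assay: the limit of > 100000 nM in this assay, at which 3 of the 4 values shown sit. It does not show that the change acts differently on the two cores: both floors lie within the usual scatter, the true size of each step stays unknown, and the earlier steps among compound 1, compound 2 and compound 3 cannot be read.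

The compounds shown leave open how large either step really is, and whether the number for compound 4 is tied to chloro in particular or would also appear with other groups on the same aromatic carbon. A bromo group or an amine at that place, or a longer chain between the oxygen and the pyridin-4-yl ring, would extend the comparison beyond these four compounds.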